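The compounds below may be only part of what the source reports. "The series", "measured", "known", "first", "only" and "open" are said of these compounds alone.

Three carbamates that share one core have been tested in a functional assay on CCRF-CEM cells (Homo sapiens) for cytotoxicity, read by MTT assay, with a stated time of 72 h; a higher number here means a weaker inhibitor of growth, a lower number a stronger inhibitor of growth. Compound 1 `CC(C)COC(=O)Nc1ccc([Se]C#N)cc1` gives 38300 nM. Compound 2 `C=CCOC(=O)Nc1ccc([Se]C#N)cc1` gives 38100 nM, and compound 3 `CCOC(=O)Nc1ccc([Se]C#N)cc1` gives 39100 nM. The steps between them are a 1.0-fold lower number from compound 1 to compound 2 (0.00 log units; within the scatter), a 1.0-fold higher number from compound 1 to compound 3 (0.01 log units; within the scatter) and a 1.0-fold higher number from compound 2 to compound 3 (0.01 log units; within the scatter); none goes beyond the scatter. Compound 3 thus holds the highest of the three numbers, yet neither its distance from compound 1 nor that from compound 2 is more than scatter.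

Compound 4 `N#C[Se]c1ccc(NC(=O)Oc2ccccc2)cc1` differs from compound 3 by phenyl in place of ethyl on an oxygen next to a carbonyl group. Among the compounds with values here, the measured steps all exchange one chain for another on the same oxygen, and each was flat in this assay, so the only guidance they offer is that swapping the group on that oxygen has not shifted the read-out. Within the data shown here, none of them, however, brings in a ring, so the change to compound 4 has no direct precedent among the measured pairs. On these data alone, on that basis compound 4 is expected to show a 1.1-fold lower number from compound 3 to compound 4 (0.04 log units; within the scatter), in effect no movement beyond the scatter, with a wide range because the ring is untested. The value estimated for compound 4 in this assay is 36000 nM, lying between 15000 nM and 85000 nM.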

Compound 4, concentration for total growth inhibition: 48000 nM
Compound 4: middle estimate off by 1.3-fold (0.12 log units), on the low side, and the stated range covers the measured number.
By their numbers in this assay, from the lowest: compounds 2, 1, 3 and 4 (each within the scatter of the next).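

In this assay, the first ring on an oxygen next to a carbonyl group gives steps that all stay within the scatter: a 1.2-fold higher number from compound 3 to compound 4 (0.09 log units; within the scatter), a 1.3-fold higher number from compound 2 to compound 4 (0.10 log units; within the scatter) and a 1.3-fold higher number from compound 1 to compound 4 (0.10 log units; within the scatter). The earlier compounds shown here showed this flat read-out only for exchanges of one chain for another, whereas these steps extend it to phenyl, a six-membered aromatic ring of carbon only with 6 heavy atoms, in place of ethyl, allyl or isobutyl, so across these four compounds the read-out does not separate a ring from a chain at this place. Nothing shown here offers an explanation for this flat read-out.

On these data alone, it remains open whether any group on this oxygen can carry the number beyond the scatter, since every step among the four compounds lies within it, and how an amine or a carboxylic acid on the phenyl, or a longer chain in its place, would read stays unknown. The compounds also leave open whether the same flat picture would hold on any cells other than those of this assay.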